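Fluorine on the Outer Ring: Expecting Compound 4

The compounds below may be only part of what the source reports. "The series", "measured", "known", "first", "only" and "open" are said of these compounds alone.

Three amides built on one shared core have been tested in an ADME assay on WI-38 cells (Homo sapiens) for cytotoxicity, read by MTT assay, with a stated time of 72 h; a higher number here means a weaker inhibitor, a lower number a stronger inhibitor. Compound 1 `O=C(CCc1cccc2c1B(O)OC2)Nc1ccccc1` gives 30000 nM. Compound 2 `O=C(CCc1cccc2c1B(O)OC2)Nc1ccc(F)cc1` differs from compound 1 by fluoro in place of hydrogen on an aromatic carbon. In this assay compound 2 gives 12000 nM, so that a 2.5-fold lower number from compound 1 to compound 2 (0.40 log units; beyond the scatter). Compound 3 `O=C(CCc1cccc2c1B(O)OC2)Nc1cccc(-c2ccccc2)c1` differs from compound 1 by phenyl in place of hydrogen on an aromatic carbon. In this assay compound 3 gives 12000 nM; here as well a 2.5-fold lower number from compound 1 to compound 3 (0.40 log units; beyond the scatter). Compound 2 and compound 3 stand level at the digits measured, within the usual scatter, so no order between them can be read.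

Compound 4 `O=C(CCc1cccc2c1B(O)OC2)Nc1cccc(-c2cccc(F)c2)c1` has not yet been measured. It differs from compound 3 by fluoro in place of hydrogen on an aromatic carbon. Among the compounds with values here, this is the same kind of change as the one between compound 1 and compound 2, fluoro in place of hydrogen on an aromatic carbon, but not the same change: in compound 2 the fluoro sits para to a large group, whereas in compound 4 it sits meta to a large group.

Because a 2.5-fold lower number from compound 1 to compound 2 (0.40 log units; beyond the scatter), a step of similar direction is expected in this assay for compound 4, with the different place leaving the size less certain. For compound 4 the expected step is a 1.7-fold lower number from compound 3 to compound 4 (0.23 log units; within the scatter). Compound 4 is therefore estimated at 7000 nM in this assay, with a likely range from 3000 nM to 20000 nM.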

Compound 4, half-maximal inhibitory concentration: 37000 nM
Compound 4: middle estimate off by 5.3-fold (0.72 log units), on the low side; the whole stated range lies below it.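

In this assay, fluoro in place of hydrogen on an aromatic carbon did not carry over from one core to the other, and the two steps run in opposite directions: the same change on two cores in this assay, a 2.5-fold lower number (0.40 log units; beyond the scatter) from compound 1 to compound 2 and a 3.1-fold higher number (0.49 log units; beyond the scatter) from compound 3 to compound 4, 7.7-fold (0.89 log units) apart, beyond the scatter of two such steps

The new step reads a 3.1-fold higher number from compound 3 to compound 4 (0.49 log units; beyond the scatter), while the whole 3-fluorophenyl group in place of hydrogen gives a 1.2-fold higher number from compound 1 to compound 4 (0.09 log units; within the scatter), so the lower number that came with phenyl in compound 3 does not persist in compound 4. This does not show what turned the direction round, since the fluoro of compound 4 sits on the added phenyl ring and that of compound 2 does not, which leaves a change of place and a change of core tied together in a single pair on each side.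

Still open, going by these compounds, is whether fluoro at one and the same place on both cores would move the number the same way, and whether the reversal belongs to fluoro alone or would also appear with chloro or methoxy. Also open, on these data alone, is how the number would respond to an amine or a carboxylic acid on the added phenyl ring, or to a longer chain leading to the amide.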